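Removing the side chain from compound 2

A few compounds are considered here, and "the series" means these few. Any claim that something is new, unique, unknown or untested is made for them only; others in the source may bear on it.

In a functional assay for inhibition (a lower number here means a stronger inhibitor, a higher number a weaker inhibitor), compound 1 `CC(C)(C)c1cc(-c2cc(=O)c3ccc(OCC(=O)N4CCCCC4)cc3o2)cc(C(C)(C)C)c1O` gives 3000 nM, and compound 2 `CCOC(=O)C(C)(C)Oc1ccc2c(=O)cc(-c3cc(C(C)(C)C)c(O)c(C(C)(C)C)c3)oc2c1` gives 3000 nM. Going by the values given here, compound 2 therefore stands level with compound 1, the only other measured compound. The next structure is compound 3 `CC(C)(C)c1cc(-c2cc(=O)c3ccccc3o2)cc(C(C)(C)C)c1O`, and the change is hydrogen in place of 1-(ethoxycarbonyl)-1-methylethoxy on an aromatic carbon. Hydrogen stands in place of 1-(ethoxycarbonyl)-1-methylethoxy on an aromatic carbon, so the whole chain goes, along with the oxygen that carries it.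

Among the compounds with values here, only one measured step bears on this, and only indirectly. Exchanging ((piperidin-1-yl)carbonyl)methyl for 1-(ethoxycarbonyl)-1-methylethyl on that oxygen gave no change at the digits printed from compound 1 to compound 2 (within the scatter). That step shows two different groups reading alike, but it replaces one group with another and does not remove either. Within the data shown here, no measured compound lacks the chain, so the size of a removal has not been observed. On the evidence of that single step, no shift beyond the scatter is expected in either direction, and the expected step is no change at the digits printed from compound 2 to compound 3 (within the scatter). Compound 3 is estimated at 3000 nM, with an expected range of 900 nM to 10000 nM.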

Compound 3, half-maximal inhibitory concentration: 3000 nM
For compound 3 middle estimate and measured number coincide at the digits printed; low and high end bracket the measured number.
By their numbers in this assay, from the lowest: compounds 1, 2 and 3 (each within the scatter of the next).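

In this assay, taking away the whole 1-(ethoxycarbonyl)-1-methylethoxy group, oxygen included, and leaving hydrogen on that aromatic carbon gives no change at the digits printed from compound 2 to compound 3 (within the scatter), and the same removal of ((piperidin-1-yl)carbonyl)methoxy gives no change at the digits printed from compound 1 to compound 3 (within the scatter). Going by these compounds alone, the earlier pair showed only that one group could stand in for another on this oxygen, whereas these steps show that the read-out holds with no side chain at all, so neither chain is required at this position for the level the three compounds share. No supporting measurement accompanies these readings that would explain them.

The compounds shown leave open whether any other group on this aromatic carbon, such as an amine, a carboxylic acid or a longer chain, would read apart from hydrogen, since the only two substituents compared here both join through an oxygen and neither separates from hydrogen. From the compounds shown here alone, they also hold the rest of the core constant, so what its remaining parts, including the hydroxyl and the two tert-butyl groups, contribute to the shared level stays unknown.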